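Adding an Amide Chain to Compound 2

This account rests on a few compounds, and the source may have more. Where it says the series, first, only, none or still open, it means among the compounds named here.

Measured compounds:
compound 1, `CCCCCCCC(=O)NCCCN1C[C@H](C)C[C@@](C)(O)[C@H](O[C@@H]2O[C@H](C)C[C@H](N(C)C)[C@H]2O)[C@@H](C)[C@H](O[C@H]2C[C@@](C)(OC)[C@@H](O)[C@H](C)O2)[C@@H](C)C(=O)O[C@H](CC)[C@@](C)(O)[C@H](O)[C@H]1C`, 3.74
compound 2, `CC[C@H]1OC(=O)[C@H](C)[C@@H](O)[C@H](C)[C@@H](O[C@@H]2O[C@H](C)C[C@H](N(C)C)[C@H]2O)[C@](C)(O)C[C@@H](C)CN(C)[C@H](C)[C@@H](O)[C@]1(C)O`, 1.35

The set holds two measured compounds and one still unmeasured. In a physicochemical assay for lipophilicity, read by HPLC, measured as chromatographic lipophilicity, at pH 7.4 (on this read-out higher numbers stand for higher lipophilicity and lower numbers for lower lipophilicity), compound 1 gives 3.74, while compound 2 gives 1.35. Compound 2 therefore stands lowest of the two numbers, and compound 1 lies beyond the scatter above it; the two structures differ in more than one place, so only the two values themselves can be compared.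

Compound 3, `CCCCCCCC(=O)NCCCN1C[C@H](C)C[C@@](C)(O)[C@H](O[C@@H]2O[C@H](C)C[C@H](N(C)C)[C@H]2O)[C@@H](C)[C@H](O)[C@@H](C)C(=O)O[C@H](CC)[C@@](C)(O)[C@H](O)[C@H]1C`, is built from compound 2 by a single change: 2-((heptylcarbonyl)amino)ethyl in place of hydrogen on a saturated chain carbon bound to an amine nitrogen in a ring. Going by the values given here, no measured pair shows this exact step on its own, so its size is not known from the data. Still, the chain that enters is also present in compound 1, whose value in this assay is well above that of compound 2. On that basis the step from compound 2 to compound 3 is expected to be upward and well beyond the scatter, estimated as a number 1.95 log units higher from compound 2 to compound 3 (beyond the scatter). For compound 3 the value in this assay is estimated at 3.3, within a range from 2.7 to 3.9.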

Compound 3, distribution coefficient: 3.08
The estimate for compound 3 lay 0.22 log units above the measured number, within the range that was stated.
By their numbers in this assay, from the lowest: compound 2; then compound 3; then compound 1.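

In this assay, the amide chain now has a step of its own at this position: 2-((heptylcarbonyl)amino)ethyl in place of hydrogen on a saturated chain carbon bound to an amine nitrogen in a ring gives a large change (a number 1.73 log units higher from compound 2 to compound 3 (beyond the scatter)). Compound 3 also separates a second change that the two earlier compounds could not show apart, since hydrogen in place of 5-hydroxy-4-methoxy-4,6-dimethyloxan-2-yl on an oxygen on a saturated carbon gives a modest change (a number 0.66 log units lower from compound 1 to compound 3 (beyond the scatter)). Both steps lie beyond the scatter, but no measurement at hand says why either has the size it has.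

The compounds shown leave open how the number would respond to a shorter or longer acyl chain, or to an amine or a carboxylic acid at the end of the chain in place of the heptylcarbonyl part. They also leave open whether the 5-hydroxy-4-methoxy-4,6-dimethyloxan-2-yl group would give a step of similar size on compound 2, which lacks the amide chain.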